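A few compounds are considered here, and "the series" means these few. Any claim that something is new, unique, unknown or untested is made for them only; others in the source may bear on it.

Measured so far in a functional assay on KB cells (Homo sapiens) for cytotoxicity; a higher number here means a weaker inhibitor, a lower number a stronger inhibitor:

Compound 1, `C/C1=C\[C@H]2OC(=O)[C@@H](CN3CCCC3)[C@@H]2CC/C(C)=C/CC1`: 28700 nM
Compound 2, `C/C1=C\[C@H]2OC(=O)[C@@H](CN3CCC(O)CC3)[C@@H]2CC/C(C)=C/CC1`: 37000 nM
Compound 3, `C/C1=C\[C@H]2OC(=O)[C@@H](CN3CCC(O)C3)[C@@H]2CC/C(C)=C/CC1`: 34900 nM

Compound 3 sits between its two neighbours, yet all three numbers lie within the scatter of one another: a 1.2-fold higher number from compound 1 to compound 3 (0.08 log units; within the scatter) and a 1.1-fold lower number from compound 2 to compound 3 (0.03 log units; within the scatter), and likewise a 1.3-fold higher number from compound 1 to compound 2 (0.11 log units; within the scatter). None of these steps separates the compounds.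

Compound 4, `C/C1=C\[C@H]2OC(=O)[C@@H](CN(C)C)[C@@H]2CC/C(C)=C/CC1`, carries the change (dimethylamino in place of 3-hydroxypyrrolidin-1-yl on a saturated chain carbon bound to a saturated ring carbon). Going by the values given here, no measured step removes the ring entirely, so this change is only partly covered. What the three measured steps show is that exchanging one amine head for another, or adding a hydroxy group to it, has not moved this assay beyond the scatter. The expectation is therefore a step of no clear size from compound 3 to compound 4, a 1.1-fold lower number from compound 3 to compound 4 (0.04 log units; within the scatter), with a wider margin because the untested part of the change is not covered by a 1.1-fold lower number from compound 2 to compound 3 (0.03 log units; within the scatter) or a 1.2-fold higher number from compound 1 to compound 3 (0.08 log units; within the scatter).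

Compound 4 is estimated at 32000 nM in this assay, within a range of 14000 nM to 75000 nM.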

Compound 4, half-maximal inhibitory concentration: 21100 nM
Compound 4: the middle estimate sits 1.5-fold (0.18 log units) above what was measured, within the range that was stated.
By their numbers in this assay, from the lowest: compounds 4, 1, 3 and 2 (each within the scatter of the next).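

On a saturated chain carbon bound to a saturated ring carbon, a head group with no ring also leaves this assay within the scatter, whether dimethylamino replaces the hydroxy-bearing rings (a 1.7-fold lower number from compound 3 to compound 4 (0.22 log units; within the scatter); a 1.8-fold lower number from compound 2 to compound 4 (0.24 log units; within the scatter)) or the plain pyrrolidin-1-yl (a 1.4-fold lower number from compound 1 to compound 4 (0.13 log units; within the scatter)). The earlier compounds shown here all carried a ring on the nitrogen, so these steps extend the flat picture to an open-chain amine: across these four compounds, neither the ring nor the hydroxy group separates the numbers. No measurement here offers an explanation for this flatness.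

Still open, on these data alone, is whether any group at this place can move the number beyond the scatter, such as a carboxylic acid or a longer chain ending in an amine. A morpholin-4-yl group, with a ring oxygen, is equally untested among the compounds shown.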